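Cytotoxicity notes on the amide series and a chloro analogue

The source may report more compounds than this note shows. Statements on the series, on what has been measured and on what is new or still open speak of the compounds shown alone.

Measured compounds, each at a limit of the assay:
compound 1 `Cn1c(-c2ccccc2)cnc1NC(=O)c1ccc(F)cc1`: > 100000 nM
compound 2 `Cn1c(-c2ccccc2)cnc1NC(=O)C1CCCCC1`: > 100000 nM
compound 3 `Cn1c(-c2ccccc2)cnc1NC(=O)c1ncc[nH]1`: > 100000 nM

In a toxicity assay on THP-1 cells (Homo sapiens) for inhibition (a lower number here means that less compound is tolerated, a higher number that more compound is tolerated), compound 1 gives > 100000 nM, which is a limit of the assay and not a number. Compound 2 gives > 100000 nM, again a limit. Compound 3 gives > 100000 nM, also a limit. The steps a step that the two limits leave unreadable from compound 1 to compound 2, a step that the two limits leave unreadable from compound 1 to compound 3 and a step that the two limits leave unreadable from compound 2 to compound 3 therefore have no readable size because of the limit of > 100000 nM in this assay, at which 3 of the 3 values shown sit. All three of them exchange the group on the carbonyl carbon and leave the rest of the shared core untouched.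

Compound 4 `Cn1c(-c2cccc(Cl)c2)cnc1NC(=O)c1ccc(F)cc1` differs from compound 1 by chloro in place of hydrogen on an aromatic carbon. Within the data shown here, no measured step touches this part of the molecule, so the measured series gives no direct guide to the size or direction of the change; it only shows that every variant so far sits at the limit. Compound 4 is expected to stay at the limit as well, with an estimate of 100000 nM and a range of 40000 nM to 250000 nM. This corresponds to an expected step of a number no higher from compound 1 to compound 4 (the limit leaves the size open), meaning no movement beyond the scatter is anticipated.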

Compound 4, half-maximal cytotoxic concentration: > 50000 nM
Compound 4: only a limit was reported (the forecaster's own chance of this, stated with the estimate: 80%); the middle value is on the limit's open side.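

No new step can be read: compound 1 and compound 4 both stand at limits of the assay, so the exchange of phenyl for 3-chlorophenyl has no readable size. The compounds shown leave open at what concentration any of them becomes cytotoxic, and whether chloro shifts that concentration.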